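The source may hold more compounds than are shown below. What is called first, only, known or untested is meant among the compounds shown, and "the series" means these compounds.

Compound 2 `COc1ccc(S(=O)(=O)Nc2ccc(C)c(Nc3nccc(-c4cc(OC)c(OC)c(OC)c4)n3)c2)cc1` holds the higher of the two numbers measured in a functional assay on MCF7 cells (Homo sapiens) for cytotoxicity, read by MTT assay, with a stated time of 24 h; on this read-out higher numbers stand for weaker inhibition and lower numbers for stronger inhibition; in this assay compound 2 gives 12300 nM. Compound 1 `COc1cc(-c2ccnc(Nc3cc(NS(=O)(=O)c4ccc(-c5ccccc5)cc4)ccc3C)n2)cc(OC)c1OC` gives 9330 nM in this assay, and the step of a 1.3-fold higher number from compound 1 to compound 2 (0.12 log units; within the scatter) lies within the scatter, so the two compounds are not told apart on these numbers. Compound 3 `COc1ccc(S(=O)(=O)Nc2ccc(C)c(Nc3nccc(-c4cc(OC)c(OC)c(OC)c4)n3)c2)cc1OC` is not yet measured; it differs from compound 2 by methoxy in place of hydrogen on an aromatic carbon. Going by the values given here, only one measured step exists, a 1.3-fold higher number from compound 1 to compound 2 (0.12 log units; within the scatter), which also changed a group on that outer ring and stayed within the scatter; no step with a change of this exact kind has been measured. On this basis the step of a 1.0-fold lower number from compound 2 to compound 3 (0.01 log units; within the scatter) is expected to remain within the scatter, with no direction beyond it. For compound 3 the estimate in this assay is 12000 nM, with a range from 5000 nM to 30000 nM.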

Compound 3, half-maximal inhibitory concentration: 11600 nM
Estimate against measurement, compound 3: 1.0-fold (0.01 log units) above, and the stated range covers the measured number.
By their numbers in this assay, from the lowest: compounds 1, 3 and 2 (each within the scatter of the next).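

In this assay, methoxy in place of hydrogen on the aromatic carbon ortho to a methoxy group and meta to a large group, which turns 4-methoxyphenyl into 3,4-dimethoxyphenyl, gives a 1.1-fold lower number from compound 2 to compound 3 (0.03 log units; within the scatter), so compounds 2 and 3 are not told apart at this position. Replacing the whole group on the sulfonyl sulfur gives a 1.2-fold higher number from compound 1 to compound 3 (0.09 log units; within the scatter), so 3,4-dimethoxyphenyl and 4-phenylphenyl are not told apart there either, and all three compounds lie within the scatter of one another. No measurement shown here accounts for these results.

As far as these compounds go, whether an amine or a carboxylic acid at this position, or a longer chain in place of the added methoxy, would stand apart from these compounds remains open. The shared core does not vary among the compounds shown, so what its parts contribute also remains open.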